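Trimming the branch: from isopropyl to ethyl

The source may hold more compounds than are shown below. What is called first, only, known or untested is meant among the compounds shown, and "the series" means these compounds.

Compound 1, `Cn1ncc2c(=O)n(-c3ccccc3)c(SC(C)(C)c3ccccc3)nc21`, gives 2200 nM in an assay on isolated protein for inhibition of retinal dehydrogenase 2 (Homo sapiens); a lower number here means a stronger inhibitor, a higher number a weaker inhibitor.
Compound 2, `Cn1ncc2c(=O)n(-c3ccccc3)c(SCc3cccc(F)c3)cc21`, gives 240 nM in this assay.
Compound 3, `CC(C)C(Sc1nc2c(cnn2C)c(=O)n1-c1ccccc1)c1ccccc1`, gives 300 nM in this assay.

Compound 3 stands second highest of the three numbers. Its nearest neighbour is compound 2, whose value lies within the scatter of compound 3; the furthest is compound 1, whose number is beyond the scatter above compound 3.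

Compound 4, `CCC(Sc1nc2c(cnn2C)c(=O)n1-c1ccccc1)c1ccccc1`, differs from compound 3 by hydrogen in place of methyl on a saturated chain carbon bound to two saturated chain carbons. Among the measured compounds shown here, no step between measured compounds covers this change. Since compound 1 with its larger branching gives 2200 nM and compound 3 a lower number, the smaller branch is expected to cost little; the step of a 1.2-fold lower number from compound 3 to compound 4 (0.08 log units; within the scatter) is expected to stay within the scatter. Compound 4 is therefore estimated at 250 nM, with a range from 100 nM to 700 nM.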

Compound 4, half-maximal inhibitory concentration: 179 nM
Estimate against measurement, compound 4: 1.4-fold (0.15 log units) above, within the range that was stated.
By their numbers in this assay, from the lowest: compounds 4, 2 and 3 (each within the scatter of the next); then compound 1.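

Trimming isopropyl to ethyl on this saturated chain carbon gives a 1.7-fold lower number from compound 3 to compound 4 (0.22 log units; within the scatter) in this assay, so the methyl that leaves can go without a change beyond the scatter. The larger difference lies on the sulfur, where 1-phenylpropyl in place of 1-methyl-1-phenylethyl gives a 12-fold lower number from compound 1 to compound 4 (1.09 log units; beyond the scatter). No measurement at hand accounts for either step. The compounds shown leave open how a longer chain such as propyl, or an amine, would read on that same carbon in this assay.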